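The source may report more compounds than this note shows. Statements on the series, on what has been measured and on what is new or still open speak of the compounds shown alone.

Measured so far:
- Compound 1, `CCOC(=O)CCCCCCn1c(CC)nc(-c2ccccc2)c1-c1ccccc1`: 11 nM
- Compound 2, `CCc1nc(-c2ccccc2)c(-c2ccccc2)n1CCCCCCCC(=O)OC`: 31 nM
- Compound 3, `CCOC(=O)CC(CC)CCCCCn1c(C)nc(-c2ccccc2)c1-c1ccccc1`: 9900 nM

In an assay on H4 cells for inhibition of Fatty-acid amide hydrolase 1 (Homo sapiens) (a higher number here means a weaker inhibitor, a lower number a stronger inhibitor), compound 3 stands clearly apart from the other two, giving the highest number of the three, far beyond the scatter from both compound 1 and compound 2. The step from compound 3 to compound 4, `CNC(=O)CCCCCCn1c(C)nc(-c2ccccc2)c1-c1ccccc1`, is (methylcarbamoyl)methyl in place of 1-((ethoxycarbonyl)methyl)propyl on a saturated chain carbon, five bonds along the chain from an aromatic nitrogen. In the words of that comparison, a branched, ester-bearing chain end gives way to a shorter, unbranched chain end that carries an amide with one hydrogen-bond donor.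

Among the compounds with values here, only one measured step touches the chain end: a 2.8-fold higher number from compound 1 to compound 2 (0.45 log units; beyond the scatter), a swap of one ester for another, and a modest one. No measured pair compares an ester with an amide, and compound 3 also differs from compounds 1 and 2 elsewhere, so the branched chain cannot be isolated as the cause of its weakness. With the branching removed, and the chain end otherwise uncertain, the expectation for compound 4 in this assay is a substantial move toward lower numbers, a 33-fold lower number from compound 3 to compound 4 (1.52 log units; beyond the scatter), though with wide uncertainty. Compound 4 is estimated at 300 nM, likely between 30 nM and 3000 nM.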

Compound 4, half-maximal inhibitory concentration: 1700 nM
Estimate against measurement, compound 4: 5.7-fold (0.75 log units) below, and the stated range covers the measured number.
By their numbers in this assay, from the lowest: compound 1; then compound 2; then compound 4; then compound 3.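

In this assay, the chain end of compound 3 can be exchanged for an amide and the number still falls, with the step of a 5.8-fold lower number from compound 3 to compound 4 (0.77 log units; beyond the scatter) showing that this position responds to a change larger than the ester-for-ester swap seen earlier. The change is a bundle, however: 1-((ethoxycarbonyl)methyl)propyl, with 9 heavy atoms and 0 hydrogen-bond donors, leaves, and (methylcarbamoyl)methyl, with 5 heavy atoms and 1 hydrogen-bond donor, enters, so the branch, the ester and the size of the group all change in the same step. Nothing measured explains why the number moves.

The compounds shown leave open which part of this bundle carries the step, a question that an unbranched ethyl ester on the core of compound 4 could help to answer by changing only the branch and chain end while keeping the ester. Also open, as far as these compounds go, is how a carboxylic acid or a primary amide at the same chain end would read in this assay on this core.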